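This account rests on a few compounds, and the source may have more. Where it says the series, first, only, none or still open, it means among the compounds named here.

Measured compounds:
compound 1 `CC(C)=CCC/C(C)=C/CC[C@@](C)(Cl)[C@H](O)Cc1c[nH]c([N+](=O)[O-])c1` — "not active" (no number reported)
compound 2 `CC(C)=CCC/C(C)=C\CC/C(C)=C\Cc1ccc[nH]1` — 24400 nM

In a functional assay on HCT-116 cells (Homo sapiens) for cytotoxicity (a higher number here means a weaker inhibitor, a lower number a stronger inhibitor), compound 1 gives "not active" (no number reported), so no number stands for it; compound 2, a chain pyrrole lacking the chlorine, hydroxyl and nitro substituents, gives 24400 nM in this assay. For the measured compounds named here, no pair here differs in one place, so nothing can be said about the size of any measured step. Compound 1 stands only as inactive, without a value to rank it against compound 2.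

Compound 3 `C/C(=C\CC[C@@](C)(Cl)[C@H](O)Cc1c[nH]c([N+](=O)[O-])c1)CC[C@@H](O)C(C)(C)O` keeps the core of compound 1 and differs at the chain terminus: 1,2-dihydroxy-2-methylpropyl in place of 2-methylprop-1-en-1-yl on a saturated chain carbon, two bonds along the chain from a double-bonded chain carbon. Going by the values given here, no measured step covers a change of this kind, so the direction cannot be read from the series. Among the compounds with values here, the only anchors are compound 1 as inactive and compound 2 as a weak inhibitor. On that basis compound 3 is expected to remain at best weakly active in this assay, with a fair chance that again only a limit is reported rather than a number. Compound 3 is estimated at 40000 nM in this assay, within a range of 10000 nM to 150000 nM.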

Compound 3, half-maximal inhibitory concentration: "not active" (no number reported)
For compound 3 the study gives words and no number; no gap can be computed for the estimate.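

In this assay compound 1 gives "not active" (no number reported) and compound 3 gives "not active" (no number reported) so no new step can be read between them. The compounds shown leave open whether 1,2-dihydroxy-2-methylpropyl in place of 2-methylprop-1-en-1-yl shifts potency at all on this core. No supporting measurement bears on this result.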